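Replacing Hydroxymethyl with Dimethylcarbamoyl on the Shared Core

The source may report more compounds than this note shows. Statements on the series, on what has been measured and on what is new or still open speak of the compounds shown alone.

In a functional assay on HEK293 cells for agonist activity at Free fatty acid receptor 1 (Homo sapiens), read by fluorescence and calcium flux, with a stated time of 10 min (a higher number here means a larger maximal response, a lower number a smaller maximal response), compound 3 `CC#C[C@@H](CC(=O)O)c1ccc(OC[C@H]2COc3ccc(CO)cc3O2)cc1` gives 42%, the lowest of the three measured values. Compound 2 `CC#C[C@@H](CC(=O)O)c1ccc(OC[C@H]2COc3ccc(OC(F)(F)F)cc3O2)cc1` gives 73%, and compound 1 `CC#C[C@@H](CC(=O)O)c1ccc(OC[C@H]2COc3ccc(OC(C)C)cc3O2)cc1` gives 90%. Compound 4 `CC#C[C@@H](CC(=O)O)c1ccc(OC[C@H]2COc3ccc(C(=O)N(C)C)cc3O2)cc1` differs from compound 3 by dimethylcarbamoyl in place of hydroxymethyl on an aromatic carbon. For the measured compounds named here, no measured step leads to a dimethylcarbamoyl, so only the two steps into hydroxymethyl bear on this change: a number 48 percentage points lower from compound 1 to compound 3 (beyond the scatter) and a number 31 percentage points lower from compound 2 to compound 3 (beyond the scatter), both large losses of maximal response. Because compound 3 sits at 42% while both other groups at this position gave higher values, a modest recovery is expected in this assay, a number 13 percentage points higher from compound 3 to compound 4 (beyond the scatter). Compound 4 is therefore estimated to give 55%, with a range from 35% to 75%.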

Compound 4, largest response reached (Emax), in percent of the reference or control that the assay uses: 32%
Beside the measured number, compound 4's estimate is 23 percentage points above it; the whole stated range lies above it.
By their numbers in this assay, from the lowest: compounds 4 and 3 (each within the scatter of the next); then compound 2; then compound 1.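

In this assay, dimethylcarbamoyl and hydroxymethyl cannot be told apart, with a number 10 percentage points lower from compound 3 to compound 4 (within the scatter). The oxygen-linked groups stand well clear of dimethylcarbamoyl, with a number 41 percentage points lower from compound 2 to compound 4 (beyond the scatter) and a number 58 percentage points lower from compound 1 to compound 4 (beyond the scatter), so among these four compounds only isopropoxy and trifluoromethoxy, the two groups attached through oxygen, give the larger maximal responses. Nothing available explains this difference. On these data alone, it remains open whether an ethoxy group would also give a large response, and whether a methyl group, attached through carbon, would fall with compound 3 and compound 4.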